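Gem-Dimethyl on the Sulfonylmethyl Arm: Expected Lipophilicity Shift

This account rests on a few compounds, and the source may have more. Where it says the series, first, only, none or still open, it means among the compounds named here.

Measured compounds:
Compound 1, `CCNC(=O)Nc1ccc(-c2nc(CS(C)(=O)=O)cc([C@]34CCOC[C@H]3C4)n2)cc1`: 3.6
Compound 2, `CS(=O)(=O)Cc1cc([C@]23CCOC[C@H]2C3)nc(-c2cccc(O)c2)n1`: 3.7
Compound 3, `CCNC(=O)Nc1ccc(-c2nc(C(C)(C)S(C)(=O)=O)cc([C@]34CCOC[C@H]3C4)n2)cc1`: 4.7

Of the compounds shown here, three have been measured in a physicochemical assay for lipophilicity; a higher number here means a more lipophilic compound, a lower number a more polar compound. Compound 1 gives 3.6, and compound 3 gives 4.7; the change between them, (1-methyl-1-(methylsulfonyl)ethyl in place of (methylsulfonyl)methyl on an aromatic carbon), made a step of a number 1.10 log units higher from compound 1 to compound 3 (beyond the scatter). Compound 2 gives 3.7, and the difference between its core and that of compound 1 is not broken down here. Compound 4, `CC(C)(c1cc([C@]23CCOC[C@H]2C3)nc(-c2cccc(O)c2)n1)S(C)(=O)=O`, is not yet measured; it carries the change (1-methyl-1-(methylsulfonyl)ethyl in place of (methylsulfonyl)methyl on an aromatic carbon). Among the measured compounds shown here, this is the same kind of change as the one from compound 1 to compound 3, though the surroundings differ: in compound 2 the place is meta to a 3-hydroxyphenyl group (7 heavy atoms), while in compound 1 it is meta to a large group. A step of a number 1.00 log units higher from compound 2 to compound 4 (beyond the scatter) in this assay is expected, because the same change gave a number 1.10 log units higher from compound 1 to compound 3 (beyond the scatter). Compound 4 is therefore estimated at 4.7, between 4.3 and 5.1.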

Compound 4, partition coefficient: 4.8
For compound 4 the middle estimate is 0.10 log units below the measured one; the measured number falls inside the stated range.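

In this assay, 1-methyl-1-(methylsulfonyl)ethyl in place of (methylsulfonyl)methyl gave a number 1.10 log units higher from compound 2 to compound 4 (beyond the scatter), and the same change gave a number 1.10 log units higher from compound 1 to compound 3 (beyond the scatter), so the step kept its printed size across these two cores. Among the compounds shown here, this rests on only two pairs with the change at the same place on the ring, and it shows nothing about other cores or other places. Nothing shown explains the size of the step.

From the compounds shown here alone, it remains open whether the step would keep its size in a compound carrying an amine or a carboxylic acid in place of the 3-hydroxyphenyl group. Also open, going by these compounds, is how a longer chain on that aromatic carbon would read.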